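Swapping an amino side chain for a trifluoromethoxyphenyl group

The source may report more compounds than this note shows. Statements on the series, on what has been measured and on what is new or still open speak of the compounds shown alone.

Measured so far in an ADME assay on Huh-7 cells (Homo sapiens) for cytotoxicity; on this read-out lower numbers stand for higher toxicity in this test and higher numbers for lower toxicity in this test:
Compound 1 `Cc1ccccc1-c1nn(-c2ccc(F)cc2F)cc1CNCCN1CCCCC1` gives > 20000 nM, which is a limit of the test rather than a number.
Compound 2 `Cc1ccccc1CNc1nn(-c2ccc(F)cc2F)cc1CNCCN1CCN(C)CC1` gives > 20000 nM, also a limit.
Compound 3 `Cc1ccccc1-c1nn(Cc2ccc(F)cc2)cc1CNCCN1CCN(C)CC1` gives > 20000 nM, also a limit.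

Compound 2 thus stands together with the other two at the limit of > 20000 nM in this assay, at which 3 of the 3 values shown sit, and no number separates any of the three. Compound 4 `CN1CCN(CCNCc2cn(-c3ccc(F)cc3F)nc2-c2ccc(OC(F)(F)F)cc2)CC1` has not yet been measured. It differs from compound 2 by 4-(trifluoromethoxy)phenyl in place of (2-methylbenzyl)amino on an aromatic carbon. Within the data shown here, no step between measured compounds shows how such a swap moves the read-out in this assay. With compound 2 sitting at the limit of > 20000 nM in this assay, at which 3 of the 3 values shown sit, like every other measured compound, the step that the limit leaves unreadable from compound 2 to compound 4 is expected to stay within the scatter. Compound 4 is therefore expected to give 30000 nM, between 10000 nM and 100000 nM, most likely reported once more only as a limit.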

Compound 4, half-maximal cytotoxic concentration: 18000 nM
Compound 4: middle estimate off by 1.7-fold (0.22 log units), on the high side; the range from low to high includes it.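

In this assay compound 4 gives 18000 nM, the first actual number among the compounds shown rather than a limit. Compound 2 gives > 20000 nM, which is a limit. Placing 4-(trifluoromethoxy)phenyl in place of (2-methylbenzyl)amino at this position gives an at least 1.1-fold lower number from compound 2 to compound 4 (0.04 log units; that floor lies within the scatter), so only a floor on the step can be read, not its true size.

The compounds shown leave open whether the trifluoromethoxy group itself matters here. A plain phenyl or a 4-methoxyphenyl group at this position would test that in this assay.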